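The source may hold more compounds than are shown below. What is called first, only, known or untested is meant among the compounds shown, and "the series" means these compounds.

Measured in a functional assay on the whole organism with Rattus norvegicus as the target; a higher number here means that more compound is needed for the effect, a lower number that less compound is needed:
- Compound 1 `Cn1c(=N)sc2cc(OC(F)(F)F)ccc21`: 5 mg/kg
- Compound 2 `CCn1c(=N)sc2cc(OC(F)(F)F)ccc21`: 5 mg/kg
- Compound 3 `N=c1sc2cc(OC(F)(F)F)ccc2n1CC(=O)O`: > 10 mg/kg, a limit

Compound 3 stands only at a limit, > 10 mg/kg, and has no exact number. Compound 4 `N=c1sc2cc(OC(F)(F)F)ccc2n1CC(N)=O` carries amino in place of hydroxy on a carbonyl carbon, carboxy to carbamoyl (amino in place of hydroxy on a carbonyl carbon). For the measured compounds named here, three measured steps bear on this change. The chain steps show no change at the digits printed from compound 1 to compound 2 (within the scatter), while the carboxy steps show an at least 2.0-fold higher number from compound 1 to compound 3 (0.30 log units; that floor lies within the scatter) and an at least 2.0-fold higher number from compound 2 to compound 3 (0.30 log units; that floor lies within the scatter). These last two are floors within the scatter, so the size of any recovery is poorly fixed. A modest move to a lower number in this assay is expected, and the estimated step is an at least 1.4-fold lower number from compound 3 to compound 4 (0.15 log units; that floor lies within the scatter). For compound 4 the expected value is 7 mg/kg, with an estimated range from 3 mg/kg to 18 mg/kg.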

Compound 4, dose for half-maximal effect: 7 mg/kg
Estimate against measurement, compound 4: no gap at the digits printed; measured number inside the range.
By their numbers in this assay, from the lowest: compounds 1, 2 and 4 (each within the scatter of the next). At a limit, above all of these: compound 3.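

In this assay, carbamoyl gives a number where carboxy gave only a limit, so amino in place of hydroxy on a carbonyl carbon can be read only as a floor, an at least 1.4-fold lower number from compound 3 to compound 4 (0.15 log units; that floor lies within the scatter). Against the smaller groups on the saturated chain carbon, carbamoyl stays within the scatter: a 1.4-fold higher number from compound 2 to compound 4 (0.15 log units; within the scatter) and a 1.4-fold higher number from compound 1 to compound 4 (0.15 log units; within the scatter). For the compounds shown here, the position therefore accepts carbamoyl with no step beyond the scatter, which the earlier compounds did not show.

As far as these compounds go, how far compound 3 truly lies from compound 4 stays open, since its value is a limit: the limit of > 10 mg/kg in this assay, at which 1 of the 4 values shown sits. Also open is how an amine, a nitrile or a longer chain would read at this position.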